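The source may report more compounds than this note shows. Statements on the series, on what has been measured and on what is new or still open speak of the compounds shown alone.

Three compounds with a shared core were examined in an assay on HEK293 cells for agonist activity at Toll-like receptor 8 (Homo sapiens), read by reporter gene assay; on this read-out lower numbers stand for an effect already at smaller amounts and higher numbers for an effect only at larger amounts of compound. Compound 1 `CCCCCn1c(N)nc2c(F)cccc21` gave "not active" (no number reported) in this assay. Compound 2 `CCCCCn1c(N)nc2c(-c3ccccc3)cccc21` likewise gave "not active" (no number reported) in this assay. For the measured compounds named here, compound 3 `CCCCCn1c(N)nc2c(O)cccc21`, which bears a hydroxy group where the other two carry fluorine or phenyl, is the one member of the set for which this assay yielded a number: compound 3 gave 5010 nM. It therefore stands alone on the numbers shown, with no second value to set it against and no step between measured compounds to judge.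

Compound 4 `CCCCCn1c(N)nc2c([N+](=O)[O-])cccc21` is the next compound to be measured. It differs from compound 3 in one place: nitro in place of hydroxy on an aromatic carbon. The hydroxy group of compound 3 is the only substituent in the set that has come with a reported number, while the fluorine of compound 1 and the phenyl of compound 2 did not. Nitro is a third substituent without a donor, and no measured pair indicates how this assay responds to it. The step from compound 3 to compound 4 in this assay is expected to be a loss, with a considerable chance that no number is reported at all, estimated as a 2.4-fold higher number from compound 3 to compound 4 (0.38 log units; beyond the scatter). For compound 4 the estimate in this assay is 12000 nM, with a range from 3000 nM to 50000 nM.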

Compound 4, half-maximal effective concentration: "not active" (no number reported)
No number was reported for compound 4; the estimate stays without a comparison.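

For the compounds shown here, compound 4, like compound 1 and compound 2, gave no number in this assay, so no step from compound 3 to compound 4 can be read. Nothing measured here bears on this result. With compound 3 at 5010 nM as the only number, the compounds shown leave open how any other substituent on that aromatic carbon would compare.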